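Swapping the amide side group on a phenylethynyl-thiazole core

This account rests on a few compounds, and the source may have more. Where it says the series, first, only, none or still open, it means among the compounds named here.

For the measured compounds named here, compound 2 `CC1CC(C(=O)N2CCc3nc(C#Cc4ccccc4)sc3C2)C1` gives 81 nM in an assay on HEK293 cells for positive allosteric modulation of metabotropic glutamate receptor 5 (Homo sapiens), read by FLIPR, with a stated time of 1 h (on this read-out higher numbers stand for an effect only at larger amounts of compound and lower numbers for an effect already at smaller amounts), and it is the only compound here with a number rather than a limit. Compound 1 `CCN1CCc2nc(C#Cc3ccccc3)sc2C1` gives > 10000 nM in this assay, a limit and not a number (the limit of > 10000 nM in this assay, at which 1 of the 2 values shown sits). Going by the values given here, the one measured step is an at least 120-fold lower number from compound 1 to compound 2 (2.09 log units; beyond the scatter). Compound 3 `O=C(CC1CCOCC1)N1CCc2nc(C#Cc3ccccc3)sc2C1` differs from compound 2 by (oxan-4-yl)methyl in place of 3-methylcyclobutyl on a carbonyl carbon. Among the compounds with values here, no measured step compares two such side groups on the carbonyl carbon, so no change beyond the scatter is expected, and the estimated step is a 1.4-fold higher number from compound 2 to compound 3 (0.13 log units; within the scatter). Compound 3 is expected to give about 110 nM, somewhere between 30 nM and 450 nM.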

Compound 3, half-maximal effective concentration: 470 nM
For compound 3 the middle estimate is 4.3-fold (0.63 log units) below the measured one; the whole stated range lies below it.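

With the carbonyl kept in place, the swap gives a 5.8-fold higher number from compound 2 to compound 3 (0.76 log units; beyond the scatter) and so shows that the group on the carbonyl carbon matters in its own right. For the compounds shown here, the one earlier step could not show this, since it replaced ethyl on the ring nitrogen with a whole amide. Nothing shown here says which part of the swap, ring size or ring oxygen, accounts for the change.

Still open, going by these compounds, is whether cyclohexylmethyl, the same group with carbon in place of the ring oxygen, would track compound 2 or compound 3, and how a straight alkyl chain would fare there.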